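Swapping Chloro for Methoxy in Compound 1

The source may hold more compounds than are shown below. What is called first, only, known or untested is meant among the compounds shown, and "the series" means these compounds.

Values in a functional assay on A549 cells (Homo sapiens) for antiproliferative activity, read by MTT assay, with a stated time of 72 h; on this read-out lower numbers stand for stronger inhibition and higher numbers for weaker inhibition:
- Compound 1 `COc1ccc(N2C(=O)COc3ccc(-c4cnc(Cl)c(NS(=O)(=O)c5ccc(F)cc5)c4)cc32)cc1`: 30400 nM
- Compound 2 `CC(C)N1C(=O)COc2ccc(-c3cnc(Cl)c(NS(=O)(=O)c4ccc(F)cc4)c3)cc21`: 5100 nM
- Compound 3 `O=C1COc2ccc(-c3cnc(Cl)c(NS(=O)(=O)c4ccc(F)cc4)c3)cc2N1c1ccc(Cl)cc1`: 21600 nM

Compound 1 stands at the high end of these numbers, and the isopropyl swap on the amide-type nitrogen gives a 6.0-fold lower number from compound 1 to compound 2 (0.78 log units; beyond the scatter). Compound 4 `COc1ccc(N2C(=O)COc3ccc(-c4cnc(OC)c(NS(=O)(=O)c5ccc(F)cc5)c4)cc32)cc1` differs from it at one place, on an aromatic carbon next to the ring nitrogen and ortho to a ((4-fluorophenyl)sulfonyl)amino group, with methoxy in place of chloro on an aromatic carbon. Going by the values given here, no measured step touches that carbon. The closest guide is the same pair of groups exchanged at a different carbon, in the opposite sense, which gives a 1.4-fold lower number from compound 1 to compound 3 (0.15 log units; within the scatter). Only a small change is therefore expected in this assay, with no firm direction. The expected step is a 1.5-fold lower number from compound 1 to compound 4 (0.18 log units; within the scatter). For compound 4 the estimated value is 20000 nM, with an expected range from 5000 nM to 60000 nM.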

Compound 4, half-maximal inhibitory concentration: 1350 nM
The estimate for compound 4 lay 15-fold (1.17 log units) above the measured number, and the stated range ends above it.
By their numbers in this assay, from the lowest: compound 4; then compound 2; then compounds 3 and 1 (each within the scatter of the next).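

Going by these compounds alone, on the aromatic carbon next to the ring nitrogen, methoxy in place of chloro gives a 23-fold lower number from compound 1 to compound 4 (1.35 log units; beyond the scatter) in this assay, so this position matters far more to the number than the earlier compounds could suggest. The same two groups exchanged the other way round at a different carbon gave only a 1.4-fold lower number from compound 1 to compound 3 (0.15 log units; within the scatter) on the same read-out, so the effect of this swap depends on where it is made. No measurement shown here explains the step.

On these data alone, whether methoxy brings a similar drop alongside the isopropyl of compound 2 stays open. So does what an amine or a longer ether such as ethoxy would do on this carbon.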